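Replacing the acid of compound 3 with a pyrrolidine amide

This account rests on a few compounds, and the source may have more. Where it says the series, first, only, none or still open, it means among the compounds named here.

In a functional assay on CHO cells for agonist activity at Free fatty acid receptor 1 (Homo sapiens), read by a luciferase reporter (a higher number here means a larger maximal response, a lower number a smaller maximal response), compound 3 `O=C(O)CSc1ccc(NCc2cccc(Oc3ccccc3)c2)cc1` gives 84%, the highest of the three measured numbers. Compound 2 `Cc1nc(-c2ccc(C(F)(F)F)cc2)sc1CNc1ccc(CCCC(=O)O)cc1` reaches 44% in this assay, and compound 1 `Cc1nc(-c2ccc(C(F)(F)F)cc2)sc1CNc1ccc(CC(=O)O)cc1` reaches 18%, both clearly lower than compound 3. Going by the values given here, the one step measured between close neighbours, a number 26 percentage points higher from compound 1 to compound 2 (beyond the scatter), lengthens the acid-bearing chain while keeping the acid itself, a modest gain.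

Compound 4 `O=C(CCc1ccc(NCc2cccc(Oc3ccccc3)c2)cc1)N1CCCC1` changes compound 3 at a different place: 2-((pyrrolidin-1-yl)carbonyl)ethyl in place of (carboxymethyl)sulfanyl on an aromatic carbon. All three measured compounds keep an acid group; the entering group has no hydrogen-bond donor, whereas the leaving group carries one. Among the compounds with values here, no measured step covers such a swap, so the step from compound 1 to compound 2 gives only a weak hint that the acid-bearing part matters. Compound 4 is therefore expected to lose a sizeable part of the response, an estimated a number 49 percentage points lower from compound 3 to compound 4 (beyond the scatter). The estimate for compound 4 in this assay is 35%, within a range from 10% to 70%.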

Compound 4, largest response reached (reported as percent of maximum), in percent of the reference or control that the assay uses: 46%
Compound 4: the middle estimate sits 11 percentage points below what was measured; the range from low to high includes it.
By their numbers in this assay, from the lowest: compound 1; then compounds 2 and 4 (each within the scatter of the next); then compound 3.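

In this assay the swap on this aromatic carbon, para to a large group, costs much of the response, with a number 38 percentage points lower from compound 3 to compound 4 (beyond the scatter) as a large step. The response does not vanish, however: compound 4, whose entering group holds no carboxylic acid and no hydrogen-bond donor, still gives 46% and so shows that an acid at this place is not needed for a measurable response. No measurement at hand explains the loss.

The swap changes the sulfur, the chain and the acid in a single move, so it stays open which of these accounts for the drop. A 2-carboxyethyl group at this place would keep the acid without the sulfur, while a piperidine amide would test whether the size of the amide ring matters.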